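The compounds below may be only part of what the source reports. "The series", "measured", "known", "first", "only" and "open" are said of these compounds alone.

Measured in a functional assay on MCF7 cells (Homo sapiens) for cytotoxicity, read by MTT assay, with a stated time of 96 h; a higher number here means a weaker inhibitor, a lower number a stronger inhibitor:
- Compound 1 `COc1cc(C(=O)c2cn(-c3ccccc3)cc2-c2cccc(Br)c2)cc(OC)c1OC`: 950 nM
- Compound 2 `COc1cccc(-c2cn(-c3ccccc3)cc2C(=O)c2cc(OC)c(OC)c(OC)c2)c1`: 180 nM

Compound 2 has the lower of the two numbers, at 180 nM. Compound 3 `COc1ccc(Br)cc1-c1cn(-c2ccccc2)cc1C(=O)c1cc(OC)c(OC)c(OC)c1` differs from compound 2 in one place. It has 5-bromo-2-methoxyphenyl in place of 3-methoxyphenyl on an aromatic carbon.

Going by the values given here, only one measured step bears on this, a 5.3-fold lower number from compound 1 to compound 2 (0.72 log units; beyond the scatter). It is modest but beyond the scatter, and it puts methoxy in place of bromo on an aromatic carbon. Compound 3 keeps a methoxy and also carries a bromo, so that step is only a loose guide. Among the compounds with values here, no measured compound has the 5-bromo-2-methoxyphenyl group. A smaller step than that one is expected in this assay, towards a higher number, though the direction is uncertain. The expected step is a 2.5-fold higher number from compound 2 to compound 3 (0.40 log units; beyond the scatter). The estimate for compound 3 is 450 nM, with an expected range of 120 nM to 1700 nM.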

Compound 3, half-maximal inhibitory concentration: 2200 nM
Beside the measured number, compound 3's estimate is 4.9-fold (0.69 log units) below it; the measured number lies above the stated range.
By their numbers in this assay, from the lowest: compound 2; then compound 1; then compound 3.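

In this assay, 5-bromo-2-methoxyphenyl in place of 3-methoxyphenyl gives a 12-fold higher number from compound 2 to compound 3 (1.09 log units; beyond the scatter) as a large step, so a methoxy on this ring does not by itself keep the lower number. Methoxy in place of hydrogen on the bromo-bearing ring gives a 2.3-fold higher number from compound 1 to compound 3 (0.36 log units; beyond the scatter) as a modest step, which shows that the gain seen with methoxy in place of bromo does not carry over to adding a methoxy while the bromo stays. Nothing available explains the rise at this position.

Still open, from the compounds shown here alone, is whether the higher number follows from the methoxy's place on the ring or from the two groups together, which a 2-methoxyphenyl compound would help to separate. Also open, going by these compounds, is how an amine or a hydroxyl on this ring would compare.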